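Double esterification of a plasma-labile carbapenem prodrug

The source may hold more compounds than are shown below. What is called first, only, known or untested is meant among the compounds shown, and "the series" means these compounds.

Three measured compounds share one core and differ only in the group on a carbonyl carbon of the ester. Compound 1 `C[C@@H](O)[C@H]1C(=O)N2C(C(=O)OCOC(=O)C(C)(C)C)=C(S[C@@H]3CN[C@H](C(=O)Nc4cccc(C(=O)O)c4)C3)[C@H](C)[C@H]12` carries tert-butyl there, compound 2 `CCC(CC)C(=O)OCOC(=O)C1=C(S[C@@H]2CN[C@H](C(=O)Nc3cccc(C(=O)O)c3)C2)[C@H](C)[C@@H]2[C@@H]([C@@H](C)O)C(=O)N12` pentan-3-yl and compound 3 `C[C@@H](O)[C@H]1C(=O)N2C(C(=O)OCOC(=O)OC3CCCCC3)=C(S[C@@H]3CN[C@H](C(=O)Nc4cccc(C(=O)O)c4)C3)[C@H](C)[C@H]12` cyclohexyloxy. In an ADME assay on a cell-free system (plasma, Rattus norvegicus) for metabolic stability, read by LC-MS, with a stated time of 60 min, at 37 degrees C, tested at 50 uM (on this read-out higher numbers stand for a more stable compound and lower numbers for a less stable compound), compound 1 gives 0%; in this assay compound 2 gives 0%; in this assay compound 3 gives 0%. The steps of no change at the digits printed from compound 1 to compound 2 (within the scatter), no change at the digits printed from compound 1 to compound 3 (within the scatter) and no change at the digits printed from compound 2 to compound 3 (within the scatter) show that none of these ester groups survives the incubation, and compound 3 stands level with compounds 1 and 2.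

Compound 4 `C[C@@H](O)[C@H]1C(=O)N2C(C(=O)OCOC(=O)OC3CCCCC3)=C(S[C@@H]3CN[C@H](C(=O)Nc4cccc(C(=O)OCOC(=O)OC5CCCCC5)c4)C3)[C@H](C)[C@H]12` adds to compound 3 the change (((cyclohexyloxycarbonyl)oxy)methyl in place of hydrogen on an oxygen next to a carbonyl group), so a second ester of the same kind appears on the oxygen next to a carbonyl group. Among the compounds with values here, no measured step bears directly on this addition; the only evidence is that every measured ester is fully consumed. Within the data shown here, it is therefore expected that compound 4 also gives no remaining compound, with a step of no change at the digits printed from compound 3 to compound 4 (within the scatter). The estimate for compound 4 in this assay is 0%, between 0% and 10%.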

Compound 4, percent of the compound remaining: 10%
The estimate for compound 4 lay 10 percentage points below the measured number; the range from low to high includes it.
By their numbers in this assay, from the lowest: compounds 1, 2, 3 and 4 (each within the scatter of the next).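

In this assay the addition of ((cyclohexyloxycarbonyl)oxy)methyl in place of hydrogen on an oxygen next to a carbonyl group gives a number 10 percentage points higher from compound 3 to compound 4 (within the scatter) and so stays inside the usual variation of the measurement. Within the data shown here, the earlier compounds varied one ester group only, while compound 4 is the first to carry a group at this second position, and this position does not separate it from compound 3 on this read-out. Nothing at hand gives a reason for the reading of compound 4.

As far as these compounds go, it remains open whether a methyl ester or an amide at this oxygen-bearing position would read any differently from ((cyclohexyloxycarbonyl)oxy)methyl. From the compounds shown here alone, it is equally open whether a second ester ending in tert-butyl or pentan-3-yl would match compound 4 in this read-out.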